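From difluoromethyl to trifluoromethyl on the shared core

This account rests on a few compounds, and the source may have more. Where it says the series, first, only, none or still open, it means among the compounds named here.

In an ADME assay on microsomes from liver (Macaca fascicularis) for metabolic stability, read by LC-MS, with a stated time of 65 min, tested at 1 uM (on this read-out higher numbers stand for a more stable compound and lower numbers for a less stable compound), compound 3 (`N#Cc1ccc2nc(-c3cncnc3C(F)F)n(C3CC3)c2c1`) gives 84%, the second highest of three numbers. Compound 1 (`Fc1cc2nc(-c3cncnc3)n(C3CC3)c2cc1F`) gives 98% and compound 2 (`Fc1cc2nc(-c3cncnc3NCCC(F)(F)F)n(C3CC3)c2cc1F`) gives 55%, both beyond the scatter from compound 3. Compound 4 (`N#Cc1ccc2nc(-c3cncnc3C(F)(F)F)n(C3CC3)c2c1`) differs from compound 3 by fluoro in place of hydrogen on a saturated chain carbon bound to an aromatic carbon and two fluorine atoms, which reads as difluoromethyl to trifluoromethyl. Among the compounds with values here, the one measured step, a number 43 percentage points lower from compound 1 to compound 2 (beyond the scatter), is large but places (3,3,3-trifluoropropyl)amino on an aromatic carbon, so it bears only weakly on this change. No step beyond the scatter is therefore expected, and the estimate is a number 1 percentage points higher from compound 3 to compound 4 (within the scatter). In this assay, compound 4 is expected at 85%, within an estimated range of 70% to 97%.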

Compound 4, percent of the compound remaining: 62%
The estimate for compound 4 lay 23 percentage points above the measured number; measured number below the stated range.
By their numbers in this assay, from the lowest: compounds 2 and 4 (each within the scatter of the next); then compound 3; then compound 1.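

In this assay, one added fluoro on this saturated chain carbon proves not to be a neutral exchange: going from difluoromethyl to trifluoromethyl gives a number 22 percentage points lower from compound 3 to compound 4 (beyond the scatter) on the shared core. Within the data shown here, the earlier compounds held no step at this position, so this is the first reading of how the read-out responds to a change here. Nothing measured here accounts for the drop.

From the compounds shown here alone, whether the same exchange would weigh as much on the core of compound 1 remains open. So does how a methyl group, a methoxy group or an amine would read at this position.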